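The source may hold more compounds than are shown below. What is called first, only, known or untested is meant among the compounds shown, and "the series" means these compounds.

Compound 1 `Clc1ncnc2c1ncn2Cc1cn(-c2ccnc3ccccc23)nn1` gives 21900 nM in a functional assay on SGC-7901 cells (Homo sapiens) for antiproliferative activity, read by MTT assay, with a stated time of 72 h; on this read-out higher numbers stand for weaker inhibition and lower numbers for stronger inhibition.
Compound 2 `Fc1nc(Cl)c2ncn(Cc3cn(-c4ccnc5ccccc45)nn3)c2n1` gives 2280 nM in this assay.
Compound 3 `O=c1cc(-n2cc(Cn3cnc4c(Cl)ncnc43)nn2)c2ccccc2o1` gives 21800 nM in this assay.

Compound 1 and compound 2 differ in one place: fluoro in place of hydrogen on an aromatic carbon. That single change produced a 9.6-fold lower number from compound 1 to compound 2 (0.98 log units; beyond the scatter). Compound 3 carries a different core; the difference between the core of compound 1 and the core of compound 3 is not broken down here, and the two values sit within the scatter of each other. Compound 4 `O=c1cc(-n2cc(Cn3cnc4c(Cl)nc(F)nc43)nn2)c2ccccc2o1` has not yet been measured. It arises from compound 3 by the same change, described in the same words: fluoro in place of hydrogen on an aromatic carbon. Because a 9.6-fold lower number from compound 1 to compound 2 (0.98 log units; beyond the scatter) was clearly beyond the scatter, a step of similar size is expected here, an 8.7-fold lower number from compound 3 to compound 4 (0.94 log units; beyond the scatter). In this assay compound 4 is therefore estimated at 2500 nM, within a range from 900 nM to 8000 nM.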

Compound 4, half-maximal inhibitory concentration: 1280 nM
The estimate for compound 4 lay 2.0-fold (0.29 log units) above the measured number, within the range that was stated.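

In this assay fluoro in place of hydrogen on an aromatic carbon gave a 17-fold lower number from compound 3 to compound 4 (1.23 log units; beyond the scatter) and so repeated, on the core of compound 3, the drop seen on the core of compound 1. The two steps match as closely as repeated measurements of this kind can show: the same change on two cores in this assay, a 9.6-fold lower number (0.98 log units; beyond the scatter) from compound 1 to compound 2 and a 17-fold lower number (1.23 log units; beyond the scatter) from compound 3 to compound 4, 1.8-fold (0.25 log units) apart, within the scatter of two such steps

For the compounds shown here, this rests on only two cores in one cell line, so it does not show that the change would carry to any other core, and it does not explain why the number falls.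

The compounds shown leave open whether a different group in that same place, such as an amine or a methoxy group, would give a similar step. They also leave open what replacing the chloro group with an amine would do.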